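The compounds below may be only part of what the source reports. "The series", "measured", "known", "first", "only" and "open" are said of these compounds alone.

Among the compounds with values here, in a functional assay on MDA-MB-231 cells (Homo sapiens) for antiproliferative activity, read by MTT assay, with a stated time of 72 h (on this read-out lower numbers stand for stronger inhibition and higher numbers for weaker inhibition), compound 1 `O=C(CCc1cccc2c1B(O)OC2)Nc1ccccc1` gives 230 nM and compound 2 `N#Cc1ccc(-c2cccc(NC(=O)CCc3cccc4c3B(O)OC4)c2)cc1` gives 380 nM, so compound 2 stands within the scatter of the only other measured number. The next structure, compound 3 `CC(=O)c1cccc(-c2cccc(NC(=O)CCc3cccc4c3B(O)OC4)c2)c1`, differs from compound 2 as follows: 3-acetylphenyl in place of 4-cyanophenyl on an aromatic carbon. In short, 3-acetylphenyl stands in place of 4-cyanophenyl on an aromatic carbon. Within the data shown here, the one measured step that bears on this is a 1.7-fold higher number from compound 1 to compound 2 (0.22 log units; within the scatter), in which 4-cyanophenyl took the place of hydrogen on an aromatic carbon. Among the measured compounds shown here, on the strength of that step alone, no change beyond the scatter is expected in this assay, in either direction, although no measurement yet covers 3-acetylphenyl. The estimated step is a 1.1-fold lower number from compound 2 to compound 3 (0.04 log units; within the scatter). Compound 3 is therefore expected at about 350 nM, with an estimated range of 150 nM to 800 nM.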

Compound 3, half-maximal inhibitory concentration: 52 nM
Compound 3: middle estimate off by 6.7-fold (0.83 log units), on the high side, and the stated range ends above it.
By their numbers in this assay, from the lowest: compound 3; then compounds 1 and 2 (each within the scatter of the next).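

In this assay, the choice of aryl group at this aromatic carbon proves to matter: 3-acetylphenyl in place of 4-cyanophenyl gives a 7.3-fold lower number from compound 2 to compound 3 (0.86 log units; beyond the scatter), a change the earlier pair, whose step stayed within the scatter, gave no sign of. Set against hydrogen at the same place, 3-acetylphenyl gives a 4.4-fold lower number from compound 1 to compound 3 (0.65 log units; beyond the scatter), so a large group here can go with a lower number and not only with an unchanged one. Nothing available accounts for this difference between the two aryl groups. The two groups differ both in what the ring carries, acetyl or nitrile, and in where it sits on the ring, and the compounds shown do not separate these two changes. On these data alone, whether an amine or a carboxylic acid in place of the acetyl group would keep the lower number also remains open.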